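The source may report more compounds than this note shows. Statements on the series, on what has been measured and on what is new or still open speak of the compounds shown alone.

Measured compounds in a toxicity assay on MDCK cells (Canis lupus familiaris) for cytotoxicity, read by crystal violet staining, with a stated time of 48 h; a lower number here means that less compound is tolerated, a higher number that more compound is tolerated:
- compound 1 `Cc1ccc2[nH]c(=O)c(CN(Cc3ccc(OCC(=O)OC(C)(C)C)cc3)Cc3ccc(C(C)(C)C)cc3)cc2c1`: compound 1 gives > 10000 nM, a limit of the assay, not a number.
- compound 2 `Cc1ccc2[nH]c(=O)c(CN(Cc3ccc(OC(F)F)cc3)Cc3ccc(C(C)(C)C)cc3)cc2c1`: compound 2 gives > 5000 nM, again a limit of the assay.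
- compound 3 `CCc1ccc2[nH]c(=O)c(CN(Cc3ccc(OC(F)F)cc3)Cc3ccc(C(C)(C)C)cc3)cc2c1`: compound 3 gives > 5000 nM, also a limit of the assay.

Compound 2 thus stands at one of the two limits seen in this assay, with no number of its own; the two other values shown are likewise limits, one at the limit of > 10000 nM in this assay, at which 1 of the 3 values shown sits, and, like compound 2, one at the limit of > 5000 nM in this assay, at which 2 of the 3 values shown sit. Both measured steps are unreadable for the same reason: a step that the two limits leave unreadable from compound 1 to compound 2 and a step that the two limits leave unreadable from compound 2 to compound 3.

Compound 4 `Cc1ccc2[nH]c(=O)c(CN(Cc3ccc(C(C)(C)C)cc3)C(C)c3ccc(N(C)C)c(Cl)c3)cc2c1` differs from compound 2 as follows: 1-(3-chloro-4-(dimethylamino)phenyl)ethyl in place of 4-(difluoromethoxy)benzyl on an amine nitrogen. Neither measured step touches this part of the molecule, and neither gives a readable size, so they offer no direction for this assay. The only thing the series shows is that all three measured compounds sit at or beyond the limits. The expectation for compound 4 is therefore a step that the limit leaves unreadable from compound 2 to compound 4, that is, no change beyond the scatter, with the estimate for compound 4 at 8000 nM (range 2500 nM to 30000 nM).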

Compound 4, half-maximal cytotoxic concentration: 9800 nM
Estimate against measurement, compound 4: 1.2-fold (0.09 log units) below; the range from low to high includes it.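

The step from compound 2 to compound 4 cannot be read in this assay: compound 2 has only a limit of the assay, with no number of its own. Still open, going by these compounds, is whether 1-(3-chloro-4-(dimethylamino)phenyl)ethyl in place of 4-(difluoromethoxy)benzyl on an amine nitrogen shifts the tolerated concentration at all, and in which direction; compound 4 alone holds a number here.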